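Morpholine urea at the piperidine carbonyl of compound 4

This account rests on a few compounds, and the source may have more. Where it says the series, first, only, none or still open, it means among the compounds named here.

Compound 1 `Cc1ccccc1C(=O)Nc1ccc(S(=O)(=O)NC2CCN(C(=O)C3CCCC3)CC2)c2ccccc12` gives 9.1 nM in an assay on L1.2 cells for binding affinity to C-C chemokine receptor type 8 (Homo sapiens); a lower number here means a stronger inhibitor, a higher number a weaker inhibitor.
Compound 2 `Cc1ccccc1C(=O)Nc1ccc(S(=O)(=O)NC2CCN(C(=O)C3CNC3)CC2)c2ccccc12` gives 1.5 nM.
Compound 3 `Cc1ccccc1C(=O)Nc1ccc(S(=O)(=O)NC2CCN(C(=O)NC(C)C)CC2)c2ccccc12` gives 77.7 nM.

Compound 3 stands highest of the three in this assay: an 8.5-fold higher number from compound 1 to compound 3 (0.93 log units; beyond the scatter) and a 52-fold higher number from compound 2 to compound 3 (1.71 log units; beyond the scatter). Compound 4 `Cc1ccccc1C(=O)Nc1ccc(S(=O)(=O)NC2CCN(C(=O)N3CCOCC3)CC2)c2ccccc12` differs from compound 3 by morpholin-4-yl in place of isopropylamino on a carbonyl carbon. Among the compounds with values here, no measured step exchanges one urea substituent for another; the steps that bear on it are the two leading into compound 3, one modest and one large, both of which pair a urea with a higher number than a ring-bearing carbonyl. Since a ring enters here while the urea remains, a step in this assay of modest size toward a lower number is expected, a 1.9-fold lower number from compound 3 to compound 4 (0.29 log units; within the scatter). Compound 4 is expected to give 40 nM, within a range from 10 nM to 160 nM.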

Compound 4, inhibition constant: 6.3 nM
Estimate against measurement, compound 4: 6.3-fold (0.80 log units) above; measured number below the stated range.
By their numbers in this assay, from the lowest: compound 2; then compounds 4 and 1 (each within the scatter of the next); then compound 3.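

In this assay, within the data shown here, the urea at this carbonyl does not by itself carry a high number: with a 12-fold lower number from compound 3 to compound 4 (1.09 log units; beyond the scatter), the first exchange of one urea substituent for another shows that this substituent matters strongly. With a 1.4-fold lower number from compound 1 to compound 4 (0.16 log units; within the scatter), the morpholin-4-yl urea cannot be told apart from the cyclopentyl amide, yet a 4.2-fold higher number from compound 2 to compound 4 (0.62 log units; beyond the scatter) leaves azetidin-3-yl with the lower number. No measured evidence accounts for these steps.

As far as these compounds go, it remains open whether an open-chain dimethylamino urea would track compound 3 or compound 4. From the compounds shown here alone, it is also open whether piperazin-1-yl, which carries a ring amine, would approach compound 2.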